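The source may report more compounds than this note shows. Statements on the series, on what has been measured and on what is new or still open speak of the compounds shown alone.

Compound 1, `C=C1C[C@]23C[C@@]1(O)CC[C@H]2c1cc(Br)c(O)c(C)c1[C@@H]3Cn1cc(-c2ccccn2)nn1`, is one of the measured compounds. In a functional assay on HL-60 cells (Homo sapiens) for cytotoxicity, read by MTT assay, with a stated time of 4 days (on this read-out higher numbers stand for weaker inhibition and lower numbers for stronger inhibition), compound 1 gives > 20000 nM, which is a limit of the assay and not a number. Compound 2, `C=C1C[C@]23C[C@@]1(O)CC[C@H]2c1cc(Br)c(O)c(C)c1[C@@H]3Cn1cc(-c2ccccc2)nn1`, gives in this assay > 20000 nM, also a limit of the assay. Compound 3, `C=C1C[C@]23C[C@@]1(O)CC[C@H]2c1ccc(O)c(C)c1[C@@H]3Cn1cc(-c2ccccc2)nn1`, gives in this assay > 20000 nM, again a limit of the assay.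

Compound 2 therefore stands at the limit of > 20000 nM in this assay, at which 3 of the 3 values shown sit, and the other two values shown stand there with it. The step from compound 1 to compound 2 is a step that the two limits leave unreadable from compound 1 to compound 2, and the step from compound 2 to compound 3 is a step that the two limits leave unreadable from compound 2 to compound 3; neither can be read, since both ends sit at the limit.

The compound still to be measured is compound 4, `C=C1C[C@]23C[C@@]1(O)CC[C@H]2c1cc(Br)c(O)c(C)c1[C@@H]3Cn1cc(-c2ccc(OC)cc2)nn1`. Compared with compound 2, the change is methoxy in place of hydrogen on an aromatic carbon. The two measured steps both bear on compound 2 as a starting point, but neither has a readable size, so they give no direction to expect beyond the scatter. Compound 4 is expected to give 25000 nM in this assay, within a range from 8000 nM to 80000 nM. The expected step from compound 2 to compound 4 is estimated as a step that the limit leaves unreadable from compound 2 to compound 4, most likely leaving compound 4 at the limit as well.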

Compound 4, half-maximal inhibitory concentration: > 20000 nM
Compound 4 was reported as a limit (the forecaster's own chance of this, stated with the estimate: 85%); the middle value does not contradict the limit.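

In this assay compound 4 gives > 20000 nM, which is a limit of the assay and not a number. The steps to compound 4 from compound 1 and from compound 2 cannot be read, as both ends of each sit at a limit: the limit of > 20000 nM in this assay, at which 4 of the 4 values shown sit.

The compounds shown leave open whether any of these group changes alters the read-out at all.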